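Series notes: methoxy for methyl, compound 2 to compound 3

This account rests on a few compounds, and the source may have more. Where it says the series, first, only, none or still open, it means among the compounds named here.

Measured so far:
compound 1 `Cc1ccccc1C(=O)NCc1ccc(CNS(=O)(=O)c2ccc(Cl)cc2)cc1`: 1 nM
compound 2 `Cc1ccccc1C(=O)NCc1ccc(CNS(=O)(=O)c2cccc(F)c2)cc1`: 100 nM

In an assay on MDA-MB-231 cells for displacement of a labelled ligand from C-X-C chemokine receptor type 4 (Homo sapiens), read by fluorescence and microscopy, with stated times of 10 min and 30 min (on this read-out higher numbers stand for an effect only at larger amounts of compound and lower numbers for an effect already at smaller amounts), compound 2 gives 100 nM and stands highest of the two numbers. Within the data shown here, the nearest is compound 1, which in this assay gives 1 nM; the single known step is a 100-fold higher number from compound 1 to compound 2 (2.00 log units; beyond the scatter), and it concerns the aryl on the sulfonyl sulfur only.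

Compound 3 `COc1ccccc1C(=O)NCc1ccc(CNS(=O)(=O)c2cccc(F)c2)cc1` is the next member. Its difference from compound 2 is methoxy in place of methyl on an aromatic carbon. This change sits on the other side of the shared core, on the ring that carries the carbonyl, and the group on the sulfonyl sulfur stays as in compound 2. Among the measured compounds shown here, no measured step touches this place, so the one step known gives no guidance for it, neither in size nor in direction.

With nothing in the data to support a move either way, the expectation is a step within the scatter, no change at the digits printed from compound 2 to compound 3 (within the scatter), and the estimate for compound 3 is therefore built around the number of compound 2. Compound 3 is expected to give about 100 nM in this assay, with a range from 25 nM to 400 nM that is kept wide for want of any step at this position.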

Compound 3, effective concentration (reported as EC, without a stated level of effect): 1000 nM
Compound 3: middle estimate off by 10-fold (1.00 log units), on the low side; measured number outside the range, above it.
By their numbers in this assay, from the lowest: compound 1; then compound 2; then compound 3.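

In this assay, the place on the ring that carries the carbonyl, ortho to a large group, turns out not to be silent: methoxy in place of methyl gives a 10-fold higher number from compound 2 to compound 3 (1.00 log units; beyond the scatter). The number therefore depends on this side of the shared core as well, whereas the earlier compounds had shown a dependence only on the aryl on the sulfonyl sulfur, and here the higher number comes with the entry of an oxygen and a hydrogen-bond acceptor that the methyl does not carry. Nothing available bears on what lies behind this step.

The compounds shown leave open whether the same change gives a step of similar size and direction with the 4-chlorophenyl on the sulfonyl sulfur, as in compound 1 at 1 nM, since methoxy has been seen only with the 3-fluorophenyl. They also leave open how this position responds to groups such as an ethoxy, a hydroxyl or an amine, and whether the rise in the number tracks the oxygen or the longer substituent.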